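A few compounds are considered here, and "the series" means these few. Any claim that something is new, unique, unknown or untested is made for them only; others in the source may bear on it.

Compound 1 `COc1ccc(C2CC2C(=O)NNc2nncc3ccccc23)cc1` is tested in a functional assay on OE21 cells (Homo sapiens) for inhibition, read by MTT assay, with a stated time of 72 h (a higher number here means a weaker inhibitor, a lower number a stronger inhibitor), and gives 48000 nM, a weak result. Compound 2 `CCOc1ccc(C2CC2C(=O)NNc2nncc3ccccc23)cc1` shares the core and differs in a single group; in this assay compound 2 gives "not determined" (no result reported), and no number stands behind it. Compound 3 `CC(C)=CCOc1ccc(C2CC2C(=O)NNc2nncc3ccccc23)cc1` is reached from compound 2 by 2-methylprop-1-en-1-yl in place of methyl on a saturated chain carbon bound to an oxygen on an aromatic ring. Going by the values given here, no measured pair shows what this change does, and compound 2 carries no value of its own, leaving the direction and size of the step in this assay open; the only anchor is compound 1. Compound 3 is expected near 40000 nM, within 10000 nM to 150000 nM.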

Compound 3, half-maximal inhibitory concentration: 38000 nM
For compound 3 the middle estimate is 1.1-fold (0.02 log units) above the measured one; the measured number falls inside the stated range.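

In this assay, putting 2-methylprop-1-en-1-yl in place of hydrogen on the saturated chain carbon bound to an oxygen on an aromatic ring gives a 1.3-fold lower number from compound 1 to compound 3 (0.10 log units; within the scatter), so this position tolerates the added group without a change beyond the usual scatter. Compound 2 has no number, so the steps to and from it cannot be read. Nothing available here explains this result. Still open, from the compounds shown here alone, is whether an amine or a carboxylic acid on that chain carbon would move the number beyond the scatter.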